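The source may report more compounds than this note shows. Statements on the series, on what has been measured and on what is new or still open speak of the compounds shown alone.

Working notes on the series.

Compound 1 `COc1cc(C)nc2n/c(=N/C(=O)c3c(-c4ccc(Cl)cc4Cl)noc3C)sn12` is the reference point. Within the data shown here, in a functional assay on the whole organism for inhibition, with Digitaria ciliaris as the target, with a stated time of 72 h, tested at 10 mg/L (a higher number here means more inhibition of growth at the concentration tested, a lower number less inhibition of growth), compound 1 gives 50.3%, the highest of the three numbers known so far. Compound 2 `COc1cc(Cl)nc(NC(=S)NC(=O)c2c(-c3ccc(Cl)cc3Cl)noc2C)n1` is built on a different core; in this assay compound 2 gives 14.6%. Compound 3 `Cc1cc(Cl)nc(NC(=S)NC(=O)c2c(-c3ccc(Cl)cc3Cl)noc2C)n1` shares the core of compound 2, and in this assay compound 3 gives 10.2%. How the core of compound 1 differs from the core of compound 3 is not broken down here.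

Between compound 3 and compound 2 there is one change: methoxy in place of methyl on an aromatic carbon. Its step in this assay is a number 4.4 percentage points higher from compound 3 to compound 2 (within the scatter).

Compound 4 `COc1cc(OC)n2s/c(=N\C(=O)c3c(-c4ccc(Cl)cc4Cl)noc3C)nc2n1` is not yet measured. It differs from compound 1 by methoxy in place of methyl on an aromatic carbon. This is the same kind of change as from compound 3 to compound 2, but the surroundings are not identical: in compound 3 the carbon is meta to a chloro group and meta to a large group, whereas in compound 1 it is part of a fused or bridged system of two rings, meta to a fused ring, meta to a methoxy group and para to a fused ring.

Among the measured compounds shown here, the only precedent, the step from compound 3 to compound 2, lies within the scatter, so the expected step from compound 1 to compound 4 in this assay is likewise small, a number 2.7 percentage points higher from compound 1 to compound 4 (within the scatter). Compound 4 is therefore estimated at 53%, with a range of 35% to 70%.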

Compound 4, percent growth inhibition at one concentration: 53.8%
Estimate against measurement, compound 4: 0.8 percentage points below, within the range that was stated.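

In this assay, methoxy in place of methyl on an aromatic carbon gives a number 3.5 percentage points higher from compound 1 to compound 4 (within the scatter). Set beside the earlier step, the change reads alike on the two cores: the same change on two cores in this assay, a number 4.4 percentage points higher (within the scatter) from compound 3 to compound 2 and a number 3.5 percentage points higher (within the scatter) from compound 1 to compound 4, 0.9 percentage points apart, within the scatter of two such steps This shows only that the change stays inside the scatter on both cores, so the two steps agree in being too small to resolve; it does not show that methoxy and methyl differ in any real way on either core, that a step of a particular size carries from one core to the other, or that the same would hold on a third core or at another concentration or in another species.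

The compounds shown leave open whether a group other than methyl and methoxy on this aromatic carbon, such as an amine, a carboxylic acid or a longer alkoxy chain, would give a step beyond the scatter on either core. They also leave open whether such a group would read alike on both cores, a question that the methyl to methoxy pairs cannot answer while their steps remain this small.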